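A dimethylphenyl swap from compound 3 to compound 4

The compounds below may be only part of what the source reports. "The series", "measured", "known", "first", "only" and "open" are said of these compounds alone.

Measured in a functional assay on KBVIN cells (Homo sapiens) for antiproliferative activity, read by sulforhodamine B assay, with a stated time of 3 days; a lower number here means that less compound is needed, a higher number that more compound is needed for the effect:
compound 1 `CCCc1ccc(-c2cc(=O)c3c(o2)C(CC)(CC)C(=O)C(CC)=C3O)cc1` gives 12.2 uM
compound 2 `CCC1=C(O)c2c(oc(-c3ccc(C)c(Cl)c3)cc2=O)C(CC)(CC)C1=O` gives 2.15 uM
compound 3 `CCC1=C(O)c2c(oc(-c3cccc(C)c3C)cc2=O)C(CC)(CC)C1=O` gives 0.85 uM

Compound 3 holds the lowest number of the three, reached by a 2.5-fold lower number from compound 2 to compound 3 (0.40 log units; beyond the scatter) and by a 14-fold lower number from compound 1 to compound 3 (1.16 log units; beyond the scatter) on the same aryl position. The third measured exchange there was a 5.7-fold lower number from compound 1 to compound 2 (0.75 log units; beyond the scatter) and it was modest. Compound 4 `CCC1=C(O)c2c(oc(-c3cc(C)ccc3C)cc2=O)C(CC)(CC)C1=O` carries 2,5-dimethylphenyl in place of 2,3-dimethylphenyl on an aromatic carbon on the aromatic carbon next to the ring oxygen. Among the measured compounds shown here, no measured pair isolates such a change. The nearest guide is compound 2 with a 2.5-fold lower number from compound 2 to compound 3 (0.40 log units; beyond the scatter) as the smallest step, so only a small upward drift is expected in this assay and nothing clearly beyond the scatter. The expected change is a 1.2-fold higher number from compound 3 to compound 4 (0.07 log units; within the scatter) as an estimate. For compound 4 the estimated value is 1 uM with an expected range from 0.4 uM to 2.8 uM here.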

Compound 4, concentration for half-maximal effect: 3.41 uM
Compound 4: middle estimate off by 3.4-fold (0.53 log units), on the low side; measured number above the stated range.
By their numbers in this assay, from the lowest: compound 3; then compounds 2 and 4 (each within the scatter of the next); then compound 1.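

In this assay, among the compounds shown here, the exchange gave a 4.0-fold higher number from compound 3 to compound 4 (0.60 log units; beyond the scatter) with the atoms unchanged, so the arrangement of the two methyl groups on this aryl ring matters on its own, which no earlier pair could show. The 2,5-dimethylphenyl compound still shows a 3.6-fold lower number from compound 1 to compound 4 (0.55 log units; beyond the scatter) but, with a 1.6-fold higher number from compound 2 to compound 4 (0.20 log units; within the scatter) between them, is not separated from the 3-chloro-4-methylphenyl compound. Nothing given here explains the difference between the two dimethylphenyl arrangements. From the compounds shown here alone, it remains open how 3,5-dimethylphenyl would compare, and whether an ethyl or methoxy group could stand in for either methyl group of 2,3-dimethylphenyl.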